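Removing the Methoxy Group from Compound 3

This account rests on a few compounds, and the source may have more. Where it says the series, first, only, none or still open, it means among the compounds named here.

Measured compounds:
compound 1 `Cc1cccc(-c2noc(COc3ccc(CCC(=O)O)cc3Cl)n2)c1`: 4580 nM
compound 2 `O=C(O)CCc1ccc(OCc2nc(-c3cccc(C(F)(F)F)c3)no2)c(Cl)c1`: 30100 nM
compound 3 `COc1cccc(-c2noc(COc3ccc(CCC(=O)O)cc3Cl)n2)c1`: 3000 nM

The three measured compounds share a core and differ only in the substituent on the outer phenyl ring. In a functional assay on CHO cells for agonist activity at Free fatty acid receptor 1 (Homo sapiens), read by FLIPR and calcium flux, in the presence of a further agent that is not named here (a higher number here means that more compound is needed for the effect, a lower number that less compound is needed), compound 3 gives 3000 nM, the lowest of the three numbers. Its nearest neighbour is compound 1 at 4580 nM; the step of a 1.5-fold lower number from compound 1 to compound 3 (0.18 log units; within the scatter) lies within the scatter, so the two cannot be ordered. Compound 2 at 30100 nM stands apart: the step of a 10-fold lower number from compound 2 to compound 3 (1.00 log units; beyond the scatter) is beyond the scatter.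

Compound 4 `O=C(O)CCc1ccc(OCc2nc(-c3ccccc3)no2)c(Cl)c1` is not yet measured. It differs from compound 3 by hydrogen in place of methoxy on an aromatic carbon. Among the compounds with values here, no measured step removes a substituent altogether; the steps that bear on it are the swap from methyl to methoxy, a 1.5-fold lower number from compound 1 to compound 3 (0.18 log units; within the scatter), which was within the scatter, and the swap from trifluoromethyl to methoxy, a 10-fold lower number from compound 2 to compound 3 (1.00 log units; beyond the scatter), which was modest and beyond the scatter. Since methyl and methoxy gave indistinguishable numbers, the bare phenyl of compound 4 is expected to land near them, most likely with a small rise in the number, a 1.8-fold higher number from compound 3 to compound 4 (0.26 log units; within the scatter), perhaps within the scatter. Compound 4 is therefore estimated at 5500 nM, with a range from 2200 nM to 16000 nM.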

Compound 4, half-maximal effective concentration: 13100 nM
The estimate for compound 4 lay 2.4-fold (0.38 log units) below the measured number; the measured number falls inside the stated range.
By their numbers in this assay, from the lowest: compounds 3 and 1 (each within the scatter of the next); then compound 4; then compound 2.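

With the substituent gone altogether, this place on the outer phenyl ring turns out not to be indifferent to what it carries, which the near-equal methyl and methoxy compounds could not show: in this assay the step is a 4.4-fold higher number from compound 3 to compound 4 (0.64 log units; beyond the scatter), and the corresponding step from the methyl compound is a 2.9-fold higher number from compound 1 to compound 4 (0.46 log units; beyond the scatter). Hydrogen is not simply the poor end of the series, however, since the step from the trifluoromethyl compound is a 2.3-fold lower number from compound 2 to compound 4 (0.36 log units; beyond the scatter), so among the three substituents shown, methyl and methoxy give lower numbers than hydrogen, while trifluoromethyl goes against that pattern by giving a higher one. No measurement here explains why these groups order as they do.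

The compounds shown leave open whether another small group at this place, such as ethoxy, hydroxyl, fluorine or nitrile, would fall with methyl and methoxy or with trifluoromethyl. They also leave open whether methoxy would give the same gain on another carbon of the ring, and whether the gain would hold with a core lacking the chlorine.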